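Para-methoxy on the phenylsulfonyl piperazine of compound 2

This account rests on a few compounds, and the source may have more. Where it says the series, first, only, none or still open, it means among the compounds named here.

Compound 2 `COC(=O)c1ccc(C2SCC(=O)N2c2ccc(N3CCN(S(=O)(=O)c4ccccc4)CC3)cn2)c(OC)c1` gives 65600 nM in a functional assay on K562 cells (Homo sapiens) for antiproliferative activity, read by MTT assay and trypan blue exclusion, with a stated time of 72 h (a higher number here means a weaker inhibitor, a lower number a stronger inhibitor), the highest of the two numbers recorded. Compound 3 `COC(=O)c1ccc(C2SCC(=O)N2c2ccc(N3CCNCC3)cn2)c(OC)c1`, the free ring amine, gives 15200 nM in this assay; the step of a 4.3-fold lower number from compound 2 to compound 3 (0.64 log units; beyond the scatter) is hydrogen in place of phenylsulfonyl on an amine nitrogen in a ring. Compound 1 `COC(=O)c1ccc(C2SCC(=O)N2c2ccc(N3CCN(Cc4cc(OC)c(OC)c(OC)c4)CC3)cn2)c(OC)c1`, carrying a trimethoxybenzyl group on the same nitrogen, reaches only a limit, > 100000 nM, that is the limit of > 100000 nM in this assay, at which 1 of the 3 values shown sits.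

Compound 4 `COC(=O)c1ccc(C2SCC(=O)N2c2ccc(N3CCN(S(=O)(=O)c4ccc(OC)cc4)CC3)cn2)c(OC)c1` is compound 2 with methoxy in place of hydrogen on an aromatic carbon; cut one bond further out, the change reads phenyl to 4-methoxyphenyl, or phenylsulfonyl to (4-methoxyphenyl)sulfonyl. For the measured compounds named here, no measured pair changes a substituent on the phenylsulfonyl ring itself. Going by the values given here, the only step touching this position, from compound 2 to compound 3, removes the whole phenylsulfonyl and is modest; the methoxy addition is a far smaller alteration, so no step beyond the scatter is expected in this assay, in either direction. The weaker end of the series sits at the limit, so a somewhat higher number for compound 4 is the more likely side of the scatter.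

Compound 4 is therefore estimated at 75000 nM, within 25000 nM to 200000 nM. The expected step of a 1.1-fold higher number from compound 2 to compound 4 (0.06 log units; within the scatter) lies within the usual scatter.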

Compound 4, half-maximal inhibitory concentration: 54500 nM
Estimate against measurement, compound 4: 1.4-fold (0.14 log units) above; the range from low to high includes it.
By their numbers in this assay, from the lowest: compound 3; then compounds 4 and 2 (each within the scatter of the next). At a limit, above all of these: compound 1.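

In this assay, for the compounds shown here, the replacement of phenyl by 4-methoxyphenyl is the first change made on the phenylsulfonyl ring itself, and it gives a 1.2-fold lower number from compound 2 to compound 4 (0.08 log units; within the scatter); methoxy on this aromatic carbon, para to a large group, therefore leaves no readable difference. The (4-methoxyphenyl)sulfonyl group also stands apart from the free ring amine, with a 3.6-fold higher number from compound 3 to compound 4 (0.55 log units; beyond the scatter), so the separation seen earlier with unsubstituted phenylsulfonyl also holds with this substituted ring. Nothing measured here gives a cause for either step.

This single substituent at a single place says nothing yet about an amine, a carboxylic acid or a fluorine atom on the same aromatic carbon, or about methoxy on another carbon of the ring. From the compounds shown here alone, whether any substituent on this ring can bring a sulfonyl compound close to compound 3, at 15200 nM, also remains open.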